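Benzofuran to Phenyl on the Amide of Compound 2

The compounds below may be only part of what the source reports. "The series", "measured", "known", "first", "only" and "open" are said of these compounds alone.

compound 1 `CN(C)CCCOc1ccc(CN2CC[C@H](NC(=O)c3ccc4ccccc4c3)C2)cc1`: < 10000 nM
compound 2 `CC(C)C[C@H](NC(=O)c1cc2ccccc2o1)C(=O)N[C@H]1CCN(Cc2ccc(OCCCN(C)C)cc2)C1`: 158 nM
compound 3 `CC(C)C[C@@H](NC(=O)c1cc2ccccc2o1)C(=O)N[C@H]1CCN(Cc2ccc(OCCCN(C)C)cc2)C1`: 3160 nM

In an assay on HEK293 cells for binding affinity to Urotensin-2 receptor (Homo sapiens), read by radioligand binding (on this read-out lower numbers stand for stronger inhibition and higher numbers for weaker inhibition), compound 1 reports only a limit, < 10000 nM, which is a limit of the assay and not a number; that limit is the limit of < 10000 nM in this assay, at which 1 of the 3 values shown sits. Compound 2 gives 158 nM, the lowest number shown. Compound 3 shares all atoms and bonds with compound 2, and a 20-fold higher number from compound 2 to compound 3 (1.30 log units; beyond the scatter); the whole of that step rests on (the fact that compounds 2 and 3 differ only in the configuration as drawn). Compound 4 `CC(C)C[C@H](NC(=O)c1ccccc1)C(=O)N[C@H]1CCN(Cc2ccc(OCCCN(C)C)cc2)C1` carries phenyl in place of 1-benzofuran-2-yl on a carbonyl carbon. No measured step touches the acyl group: the only step shown concerns configuration, so there is no direct precedent for removing the fused ring. Compound 4 is expected to give about 500 nM, with a range of 150 nM to 2000 nM. This estimate corresponds to an expected change of a 3.2-fold higher number from compound 2 to compound 4 (0.50 log units; beyond the scatter).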

Compound 4, inhibition constant: 501 nM
The estimate for compound 4 lay 1.0-fold (0.00 log units) below the measured number; the range from low to high includes it.
By their numbers in this assay, from the lowest: compound 2; then compound 4; then compound 3.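

In this assay, the acyl group responds to change, but only moderately: phenyl in place of 1-benzofuran-2-yl on a carbonyl carbon gives a 3.2-fold higher number from compound 2 to compound 4 (0.50 log units; beyond the scatter), so the fused ring system is not required for a measurable value. This step is smaller than the configurational one, a 20-fold higher number from compound 2 to compound 3 (1.30 log units; beyond the scatter). Nothing available gives a cause for the acyl step.

Still open, as far as these compounds go, is whether the step follows the ring oxygen or the fused ring itself; a furan on the same carbonyl carbon would help separate the two.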